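Chloro for methoxy on the aryl ether of compound 2

The compounds below may be only part of what the source reports. "The series", "measured", "known", "first", "only" and "open" are said of these compounds alone.

For the measured compounds named here, compound 2 `COc1ccc(OCCCON2C(N)=NC(N)=NC23CCOCC3)cc1` stands highest of the three numbers so far in a functional assay on HL-60 cells (Homo sapiens) for antiproliferative activity, read by MTT assay, with a stated time of 72 h (a higher number here means a weaker inhibitor, a lower number a stronger inhibitor), where compound 2 gives 1670 nM. Compound 3 `NC1=NC2(CCSCC2)N(OCCCOc2ccccc2Cl)C(N)=N1` gives 390 nM in this assay, and compound 1 `NC1=NC2(CCSCC2)N(OCCCOc2ccc(Cl)c(Cl)c2)C(N)=N1` gives 140 nM; both carry a different core from compound 2, so their gap to compound 2 cannot be read as an aryl effect alone. Compound 4 `NC1=NC2(CCOCC2)N(OCCCOc2cccc(Cl)c2)C(N)=N1` keeps the core of compound 2 and differs by 3-chlorophenyl in place of 4-methoxyphenyl on an oxygen on a saturated carbon. Going by the values given here, the one measured step on the aryl group, a 2.8-fold higher number from compound 1 to compound 3 (0.44 log units; beyond the scatter), shows that the chlorine pattern on the aryl ether moves this assay by a modest amount on the core of compound 1. Among the compounds with values here, no measured step isolates the aryl change on the core of compound 2; what the numbers show is that both chlorophenyl compounds sit well below compound 2. Compound 4 is therefore expected to give a lower number than compound 2, a step of a 3.0-fold lower number from compound 2 to compound 4 (0.48 log units; beyond the scatter), with an estimated 550 nM and a range from 200 nM to 1500 nM.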

Compound 4, half-maximal inhibitory concentration: 520 nM
Estimate against measurement, compound 4: 1.1-fold (0.02 log units) above, and the stated range covers the measured number.
By their numbers in this assay, from the lowest: compound 1; then compounds 3 and 4 (each within the scatter of the next); then compound 2.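

With the core of compound 2 held constant, the aryl exchange gives a 3.2-fold lower number from compound 2 to compound 4 (0.51 log units; beyond the scatter) in this assay, so the group on this oxygen changes the number without any change to the core. Earlier compounds showed an aryl effect only on the core of compound 1, and only between two chlorophenyl groups; this step extends it to the core of compound 2 and to a change from 4-methoxyphenyl to 3-chlorophenyl. No measurement offered here explains the step.

The step changes both the substituent and its printed ring position, so its contributions stay unresolved; 4-chlorophenyl or 3-methoxyphenyl on the core of compound 2 would separate them. Going by these compounds, whether 3,4-dichlorophenyl gives a similar step on this core also remains open.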